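Fluoro to Methoxy on the Shared Core: Compound 3

The source may report more compounds than this note shows. Statements on the series, on what has been measured and on what is new or still open speak of the compounds shown alone.

Compound 1: `COc1ccc2nc(NC(=O)c3cn(-c4ccccc4)nc3-c3ccc(F)cc3)sc2c1`, 12800 nM in a functional assay on PC-3 cells (Homo sapiens) for cytotoxicity, read by MTT assay, with a stated time of 72 h; on this read-out lower numbers stand for stronger inhibition and higher numbers for weaker inhibition.
Compound 2: `O=C(Nc1nc2ccc(F)cc2s1)c1cn(-c2ccccc2)nc1-c1ccc(Cl)cc1`, 5790 nM in this assay.

Compound 2 gives the lower of the two numbers, and its gap to compound 1 lies beyond the usual scatter. Compound 3, `COc1ccc2nc(NC(=O)c3cn(-c4ccccc4)nc3-c3ccc(Cl)cc3)sc2c1`, differs from compound 2 by methoxy in place of fluoro on an aromatic carbon. Among the compounds with values here, no direct step of this kind has been measured; compound 1 also carries methoxy at this place, but differs from compound 2 in a second spot as well, so its higher value cannot be assigned to one change alone. A step beyond the scatter toward a higher number is expected for compound 3, as a 1.6-fold higher number from compound 2 to compound 3 (0.19 log units; within the scatter). Compound 3 is therefore estimated at 9000 nM, between 3000 nM and 25000 nM.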

Compound 3, half-maximal inhibitory concentration: 29300 nM
Compound 3: the middle estimate sits 3.3-fold (0.51 log units) below what was measured; the measured number lies above the stated range.
By their numbers in this assay, from the lowest: compound 2; then compound 1; then compound 3.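

Methoxy in place of fluoro at this aromatic carbon can now be read on its own in this assay as a 5.1-fold higher number from compound 2 to compound 3 (0.70 log units; beyond the scatter) and so weakens inhibition while the chloro group stays fixed. With methoxy held fixed, chloro in place of fluoro at the second spot gives a 2.3-fold higher number from compound 1 to compound 3 (0.36 log units; beyond the scatter) and so also weakens inhibition, making compound 3, which carries both groups, the weakest of the three. Nothing available explains either step.

From the compounds shown here alone, whether a hydroxyl group, an amine or a longer alkoxy chain at this carbon would lower or raise the number stays open. So does the size of the methoxy step when fluoro occupies the second spot.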